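Swapping a Small Ring for a Fluorinated Chain

A few compounds are considered here, and "the series" means these few. Any claim that something is new, unique, unknown or untested is made for them only; others in the source may bear on it.

Of the compounds shown here, two built on a shared core have been tested in an ADME assay on cells (Homo sapiens) for cytotoxicity, read by polymerase chain reaction, with a stated time of 3 days; on this read-out lower numbers stand for higher toxicity in this test and higher numbers for lower toxicity in this test. Compound 1 `Nc1nc(Cl)c(-c2nc3ccccc3s2)c(N[C@@H]2C[C@H](CO)[C@@H](O)[C@H]2O)n1` gives 14000 nM in this assay. Compound 2 `Cc1nc(NCC2CC2)nc(N[C@@H]2C[C@H](CO)[C@@H](O)[C@H]2O)c1-c1nc2ccccc2s1` gives 8000 nM, the lower of the two numbers, but the gap to compound 1 falls within the ordinary scatter of repeated runs, so the two compounds cannot be told apart on this evidence.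

Compound 3 `Cc1nc(NCCCC(F)(F)F)nc(N[C@@H]2C[C@H](CO)[C@@H](O)[C@H]2O)c1-c1nc2ccccc2s1` has not yet been measured. It differs from compound 2 in one place: 3,3,3-trifluoropropyl in place of cyclopropyl on a saturated chain carbon bound to a nitrogen on an aromatic ring. Within the data shown here, no measured pair in this set shares this kind of change, so there is no direct precedent for its effect on the half-maximal cytotoxic concentration.

With nothing in the data pointing either way, the step of no change at the digits printed from compound 2 to compound 3 (within the scatter) is expected to stay inside the scatter, in no particular direction. For compound 3 the estimate in this assay is 8000 nM, with a likely range from 3000 nM to 20000 nM.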

Compound 3, half-maximal cytotoxic concentration: 3000 nM
Estimate against measurement, compound 3: 2.7-fold (0.43 log units) above, and the stated range covers the measured number.
By their numbers in this assay, from the lowest: compound 3; then compounds 2 and 1 (each within the scatter of the next).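

In this assay, putting 3,3,3-trifluoropropyl in place of cyclopropyl on a saturated chain carbon bound to a nitrogen on an aromatic ring gives a 2.7-fold lower number from compound 2 to compound 3 (0.43 log units; beyond the scatter). This shows that the group at this position can shift the read-out by a modest but real amount, with compound 3 the more toxic of the pair in this test. No measurement shown here offers an explanation for the step.

The change removes a ring and adds fluorine in one move, so the compounds shown cannot say which of the two matters. A plain propyl group with no fluorine at the same place would separate these two parts of the change, and a longer fluorinated chain would show whether the trend continues.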